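The source may report more compounds than this note shows. Statements on the series, on what has been measured and on what is new or still open speak of the compounds shown alone.

Compound 1 `CCCCCc1cn(C(c2ccccc2)c2cc3cc(Br)ccc3nc2OC)nn1` gives 11.4% in an ADME assay on PC-3 cells (Homo sapiens) for cytotoxicity, read by sulforhodamine B assay, with a stated time of 48 h, tested at 10 uM; a lower number here means less inhibition, a higher number more inhibition at the concentration tested (going by the name of the read-out). Compound 2 `COc1nc2ccc(Br)cc2cc1C(c1ccccc1)n1cc(-c2ccc(F)cc2)nn1` gives 16.4% in this assay.

Within the data shown here, compound 2 stands with compound 1 as its only neighbour; the step of a number 5 percentage points higher from compound 1 to compound 2 (within the scatter) is within the scatter, so neither is set apart. Compound 3 `COc1nc2ccc(Br)cc2cc1C(c1ccccc1)n1cc(CCCCCO)nn1` differs from compound 2 by 5-hydroxypentyl in place of 4-fluorophenyl on an aromatic carbon. Among the measured compounds shown here, the one measured step at this position, pentyl to 4-fluorophenyl, changed little; a return from 4-fluorophenyl to a five-carbon chain, now bearing a hydroxyl, is expected to change little as well, with no step beyond the scatter in this assay. Compound 3 is estimated at 12%, range 0% to 25%, a step of a number 4.4 percentage points lower from compound 2 to compound 3 (within the scatter) expected.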

Compound 3, a percentage reported as inhibition, at one concentration (the size of the read-out at that concentration, not a potency): 12.9%
Compound 3: middle estimate off by 0.9 percentage points, on the low side; the range from low to high includes it.
By their numbers in this assay, from the lowest: compounds 1, 3 and 2 (each within the scatter of the next).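

In this assay, 5-hydroxypentyl in place of 4-fluorophenyl removes the aromatic ring and adds a hydrogen-bond donor and acceptor, yet gives a number 3.5 percentage points lower from compound 2 to compound 3 (within the scatter) in the read-out. Hydroxy in place of hydrogen on the pentyl chain gives a number 1.5 percentage points higher from compound 1 to compound 3 (within the scatter), so pentyl, 4-fluorophenyl and 5-hydroxypentyl all lie within the scatter of each other at this position. Nothing at hand bears on the reason for this.

On these data alone, whether a terminal amine, a carboxylic acid or a longer chain at this position would give a step beyond the scatter remains open.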